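Para-chloro on the anilino ring of a diaryl urea

The source may report more compounds than this note shows. Statements on the series, on what has been measured and on what is new or still open speak of the compounds shown alone.

Two diaryl ureas sharing a benzoate-bearing core have been measured. In a functional assay on HT-29 cells (Homo sapiens) for antiproliferative activity, read by MTT assay, with a stated time of 48 h (on this read-out higher numbers stand for weaker inhibition and lower numbers for stronger inhibition), compound 2 `O=C(Nc1ccccc1)Nc1ccc(OC(=O)c2ccccc2)cc1` gives 123000 nM, while compound 1 `O=C(Nc1ccc(OC(=O)c2ccccc2)cc1)Nc1ccc(Cl)c(C(F)(F)F)c1` gives 151000 nM; the two numbers lie within the usual scatter of each other, so no order can be drawn between them. Compound 3 `O=C(Nc1ccc(Cl)cc1)Nc1ccc(OC(=O)c2ccccc2)cc1` differs from compound 2 by a single change: chloro in place of hydrogen on an aromatic carbon. Among the compounds with values here, with no measured step for this change, the expected step of a 1.1-fold higher number from compound 2 to compound 3 (0.02 log units; within the scatter) in this assay is none beyond the scatter. Compound 3 is thus estimated at 130000 nM, within 60000 nM to 280000 nM.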

Compound 3, half-maximal inhibitory concentration: 56000 nM
For compound 3 the middle estimate is 2.3-fold (0.37 log units) above the measured one; measured number below the stated range.
By their numbers in this assay, from the lowest: compound 3; then compounds 2 and 1 (each within the scatter of the next).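

In this assay, within the data shown here, chloro para to a large group is the first single change here to shift the number beyond the scatter, a 2.2-fold lower number from compound 2 to compound 3 (0.34 log units; beyond the scatter). Hydrogen in place of trifluoromethyl on the chlorinated ring also lowers it, a 2.7-fold lower number from compound 1 to compound 3 (0.43 log units; beyond the scatter), so the chloro step does not carry over to compound 1, which holds both groups and stays within the scatter of compound 2. Nothing available accounts for either step. As far as these compounds go, whether the step is specific to chloro stays open: fluoro, bromo or methoxy at this place would test it.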